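The source may report more compounds than this note shows. Statements on the series, on what has been measured and on what is new or still open speak of the compounds shown alone.

Measured so far in an assay on CHO cells for antagonist activity at transient receptor potential cation channel subfamily V member 1 (Homo sapiens), read by FLIPR; on this read-out lower numbers stand for stronger inhibition and higher numbers for weaker inhibition:
compound 1, `CC(C(=O)NCc1ccc(C(F)(F)F)cc1N1CCC(C(F)(F)F)CC1)c1ccc(NS(C)(=O)=O)c(F)c1`, gives 0.4 nM
compound 2, `CCCCCCSc1cc(C(F)(F)F)ccc1CNC(=O)C(C)c1ccc(NS(C)(=O)=O)c(F)c1`, gives 1.8 nM
compound 3, `CC(C(=O)NCc1ccc(C(F)(F)F)cc1SC1CCCCC1)c1ccc(NS(C)(=O)=O)c(F)c1`, gives 0.5 nM

Compound 3 holds the second highest of the three numbers. Its nearest neighbour is compound 1, with a 1.3-fold higher number from compound 1 to compound 3 (0.10 log units; within the scatter); its furthest is compound 2, with a 3.6-fold lower number from compound 2 to compound 3 (0.56 log units; beyond the scatter).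

Compound 4, `CCCCCc1cc(C(F)(F)F)ccc1CNC(=O)C(C)c1ccc(NS(C)(=O)=O)c(F)c1`, differs from compound 3 by pentyl in place of cyclohexylsulfanyl on an aromatic carbon. The step that bears on this is the one from chain to ring on the sulfur, a 3.6-fold lower number from compound 2 to compound 3 (0.56 log units; beyond the scatter), which lowered the number. Compound 4 returns to a chain, though a shorter one and without the sulfur, so a modest step back toward the number of compound 2 is expected, a 5.0-fold higher number from compound 3 to compound 4 (0.70 log units; beyond the scatter). Compound 4 is therefore estimated at 2.5 nM, with a range from 0.8 nM to 8 nM.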

Compound 4, inhibition constant: 0.4 nM
Beside the measured number, compound 4's estimate is 6.3-fold (0.80 log units) above it; the measured number lies below the stated range.
By their numbers in this assay, from the lowest: compounds 1, 4 and 3 (each within the scatter of the next); then compound 2.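

In this assay, a plain pentyl chain with no ring and no sulfur holds up on this aromatic carbon: replacing cyclohexylsulfanyl gives a 1.3-fold lower number from compound 3 to compound 4 (0.10 log units; within the scatter), and replacing 4-(trifluoromethyl)piperidin-1-yl gives no change at the digits printed from compound 1 to compound 4 (within the scatter). An open chain as such therefore does not bring the weaker number, as replacing hexylsulfanyl with pentyl gives a 4.5-fold lower number from compound 2 to compound 4 (0.65 log units; beyond the scatter). Nothing given here offers a reason for this.

As far as these compounds go, what a hexyl group directly on this carbon would give stays open, so chain length and sulfur cannot be told apart in compound 2. From the compounds shown here alone, a primary amine or a carboxylic acid at this place also remains open.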